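This account rests on a few compounds, and the source may have more. Where it says the series, first, only, none or still open, it means among the compounds named here.

In a functional assay on Jurkat cells (Homo sapiens) for cytotoxicity, with a stated time of 48 h (a lower number here means a stronger inhibitor, a higher number a weaker inhibitor), compound 1 `CCCc1ccc2c(c1)C(CC(=O)OCC)C(C(=O)OCC)=C(N)O2` gives 57300 nM and compound 2 `CCOC(=O)CC1C(C(=O)OCC)=C(N)Oc2ccc(-c3ccc(C(C)(C)C)cc3)cc21` gives 35500 nM, so compound 2 stands level with compound 1 within the scatter. Compound 3 `CCOC(=O)CC1C(C(=O)OCC)=C(N)Oc2ccc(-c3cc(O)cc(OC)c3)cc21` keeps the shared core and carries 3-hydroxy-5-methoxyphenyl in place of 4-(tert-butyl)phenyl on the same aromatic carbon: 3-hydroxy-5-methoxyphenyl in place of 4-(tert-butyl)phenyl on an aromatic carbon. Going by the values given here, only one measured step bears on this position, and it is a 1.6-fold lower number from compound 1 to compound 2 (0.21 log units; within the scatter). That exchange of propyl for an aryl group did not move the number beyond the scatter. Among the compounds with values here, no measured compound carries a hydroxy or methoxy group on the aryl ring, so the data set no direction for this change. No step beyond the scatter is therefore expected in this assay, and the estimated step is a 1.4-fold lower number from compound 2 to compound 3 (0.14 log units; within the scatter). For compound 3 the expected value is 26000 nM, with an estimated range of 9000 nM to 60000 nM.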

Compound 3, half-maximal inhibitory concentration: 4200 nM
Compound 3: middle estimate off by 6.2-fold (0.79 log units), on the high side, and the stated range ends above it.
By their numbers in this assay, from the lowest: compound 3; then compounds 2 and 1 (each within the scatter of the next).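

At this aromatic carbon the number in this assay does respond to the substituent: replacing 4-(tert-butyl)phenyl with 3-hydroxy-5-methoxyphenyl gives a step beyond the scatter (an 8.5-fold lower number from compound 2 to compound 3 (0.93 log units; beyond the scatter)), and the same group set against propyl gives a larger one (a 14-fold lower number from compound 1 to compound 3 (1.13 log units; beyond the scatter)). An aryl ring at this carbon is therefore not enough on its own, since compound 2 stands level with compound 1 within the scatter, and the two aryl groups differ in what their rings carry, with a hydrogen-bond donor and acceptors only in the entering group. No measurement available here accounts for the step.

The compounds shown leave open whether the hydroxy group or the methoxy group alone gives this step. Also open, from the compounds shown here alone, is whether an amine or a carboxylic acid on the same aryl ring would give a comparable one.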